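This account rests on a few compounds, and the source may have more. Where it says the series, first, only, none or still open, it means among the compounds named here.

In a functional assay on MDA-MB-468 cells (Homo sapiens) for antiproliferative activity, read by sulforhodamine B assay, with a stated time of 72 h (a lower number here means a stronger inhibitor, a higher number a weaker inhibitor), compound 2 `Fc1ccc(/C=C\c2cc3ccccc3nc2Cl)cc1` gives 5290 nM, within the scatter of compound 1 `FC(F)(F)c1ccc(/C=C\c2cc3ccccc3nc2Cl)cc1` at 7380 nM. Compound 3 `Fc1ccc(/C=C/c2cc3ccccc3nc2Cl)cc1` is the configurational partner of compound 2: the two compounds have the same atoms and bonds and differ only in configuration as drawn: 1 of 1 stereo elements differ; a double bond is drawn Z in compound 2 and E in compound 3. For the measured compounds named here, the only measured step, a 1.4-fold lower number from compound 1 to compound 2 (0.14 log units; within the scatter), exchanges trifluoromethyl for fluoro with the double bond drawn Z throughout, so it does not test configuration. Going by the values given here, no measured pair does, and any expectation in this assay remains tentative. A modest move to a higher number is expected, as the estimated 1.7-fold higher number from compound 2 to compound 3 (0.23 log units; within the scatter). The estimate for compound 3 is 9000 nM, with an expected range of 3000 nM to 30000 nM.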

Compound 3, half-maximal inhibitory concentration: 120 nM
Compound 3: middle estimate off by 75-fold (1.88 log units), on the high side; measured number outside the range, below it.
By their numbers in this assay, from the lowest: compound 3; then compounds 2 and 1 (each within the scatter of the next).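

In this assay, for the compounds shown here, the double bond gives the first step beyond the scatter: a 44-fold lower number from compound 2 to compound 3 (1.64 log units; beyond the scatter). The step can be assigned to configuration alone because no other part of the structure changes: the fact that compounds 2 and 3 differ only in the configuration as drawn

Going by these compounds, the exchange of trifluoromethyl for fluoro has been read only with the double bond drawn Z, so its size with the double bond drawn E stays open. Also open, on these data alone, is whether an amine or a carboxylic acid in place of fluoro would keep the number of compound 3.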